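The compounds below may be only part of what the source reports. "The series", "measured", "known", "first", "only" and "open" are said of these compounds alone.

Compound 1 `CCOC(CC(=O)O)c1ccc(OCC2COc3ccc(Cl)cc3O2)cc1`: 640 nM
Compound 2 `Cn1cncc1C(CC(=O)O)c1ccc(OCC2COc3ccc(Cl)cc3O2)cc1`: 3060 nM
Compound 3 `O=C(O)CC(c1ccncc1)c1ccc(OCC2COc3ccc(Cl)cc3O2)cc1`: 1170 nM

All three share one core and differ only in the group on the saturated chain carbon bound to an aromatic carbon and a saturated chain carbon. In a functional assay on HEK293 cells for agonist activity at Free fatty acid receptor 1 (Homo sapiens), read by fluorescence and calcium flux, with a stated time of 10 min (a higher number here means that more compound is needed for the effect, a lower number that less compound is needed), compound 1 gives the lowest of the three numbers; the gap to compound 3 lies within the scatter, while the step of a 4.8-fold higher number from compound 1 to compound 2 (0.68 log units; beyond the scatter) lies beyond it. Compound 4 `O=C(O)CC1(c2ccc(OCC3COc4ccc(Cl)cc4O3)cc2)COC1` has not been measured. Its change from compound 1 is 3-(carboxymethyl)oxetan-3-yl in place of 2-carboxy-1-ethoxyethyl on an aromatic carbon. Among the compounds with values here, no measured step closes a ring like this; the two steps that swap out the ethoxy, a 4.8-fold higher number from compound 1 to compound 2 (0.68 log units; beyond the scatter) and a 1.8-fold higher number from compound 1 to compound 3 (0.26 log units; within the scatter), both moved upward. A modest rise is therefore expected, a 2.0-fold higher number from compound 1 to compound 4 (0.31 log units; beyond the scatter). Compound 4 is estimated at 1300 nM, within a range of 400 nM to 4500 nM.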

Compound 4, half-maximal effective concentration: 8060 nM
The estimate for compound 4 lay 6.2-fold (0.79 log units) below the measured number; measured number outside the range, above it.
By their numbers in this assay, from the lowest: compounds 1 and 3 (each within the scatter of the next); then compound 2; then compound 4.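

In this assay, joining the chain carbon into an oxetane ring gives a 13-fold higher number from compound 1 to compound 4 (1.10 log units; beyond the scatter), the largest step in this set. The group that leaves and the group that enters hold the same heavy atoms and the same donor and acceptor counts, so at this position the number depends on how those atoms are connected, not only on which atoms are present. Nothing available here explains the rise.

Still open, going by these compounds, is whether the ring closure or the ring oxygen matters more. A cyclobutane ring in place of the oxetane would separate the two.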